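Aryl to methyl at the shared core: compound 4

The source may hold more compounds than are shown below. What is called first, only, known or untested is meant among the compounds shown, and "the series" means these compounds.

Measured so far in a functional assay on AGS cells (Homo sapiens) for cytotoxicity, read by MTT assay, with a stated time of 48 h; on this read-out lower numbers stand for stronger inhibition and higher numbers for weaker inhibition:
- compound 1 `Cc1nc2c3ccccc3ccc2c2nc3c(ccc4ccccc43)c(-c3ccccc3S)c12`: 4070 nM
- compound 2 `Cc1ccc(-c2c3ccc4ccccc4c3nc3c2c(C)nc2c4ccccc4ccc32)cc1`: reaches only the assay limit, > 80000 nM
- compound 3 `Cc1nc2c3ccccc3ccc2c2nc3c(ccc4ccccc43)c(-c3cccc([N+](=O)[O-])c3)c12`: 25500 nM

Among the two numbers in hand, compound 3 stands highest; the step of a 6.3-fold higher number from compound 1 to compound 3 (0.80 log units; beyond the scatter) separates it from its nearest neighbour. Compound 2 gives no number but a limit (the limit of > 80000 nM in this assay, at which 1 of the 3 values shown sits), so the step of an at least 3.1-fold lower number from compound 2 to compound 3 (0.49 log units; beyond the scatter) is itself only a bound, as is an at least 19-fold higher number from compound 1 to compound 2 (1.29 log units; beyond the scatter).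

Compound 4 `Cc1nc2c3ccccc3ccc2c2nc3c(ccc4ccccc43)c(C)c12` is reached from compound 3 by methyl in place of 3-nitrophenyl on an aromatic carbon. All three measured steps swap one aryl group for another on the same aromatic carbon; none removes the aryl group altogether, so they only show that this position moves the read-out widely and in no simple order. Direct guidance for a methyl there is absent, and the estimate stays broad.

The expected step is a 1.2-fold higher number from compound 3 to compound 4 (0.07 log units; within the scatter), a change not clearly beyond the scatter. Compound 4 is therefore estimated at 30000 nM, within 8000 nM to 90000 nM.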

Compound 4, half-maximal inhibitory concentration: > 80000 nM
Compound 4 ended at the assay's limit; the forecaster's own chance of this, stated with the estimate: 30%; at least 2.6-fold (0.42 log units) between middle value and limit.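

Taking the aryl group off altogether gives the first reading of this aromatic carbon without a ring on it: in this assay, the methyl of compound 4 returns only an assay limit, > 80000 nM. Against the two aryl compounds with numbers, the change reads as an at least 3.1-fold higher number from compound 3 to compound 4 (0.49 log units; beyond the scatter) and an at least 19-fold higher number from compound 1 to compound 4 (1.29 log units; beyond the scatter), both of them bounds, so an aryl group goes with a measurable value in those two cases, while compound 2, with its 4-methylphenyl, goes against that pattern. The step between compound 2 and compound 4 cannot be read, because both stand at a limit: the limit of > 80000 nM in this assay, at which 2 of the 4 values shown sit.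

Open, from the compounds shown here alone, is whether the sulfanyl group of compound 1 or the phenyl ring that holds it accounts for its lower number. An amine or a carboxylic acid on this carbon, in place of methyl, would show whether a group without a ring can give a measurable value at all.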